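The source may report more compounds than this note shows. Statements on the series, on what has been measured and on what is new or still open speak of the compounds shown alone.

Measured in an assay on isolated protein for inhibition of protein deacetylase HDAC6 (Homo sapiens), read by fluorescence, with stated times of 10 min and 2 h; on this read-out lower numbers stand for stronger inhibition and higher numbers for weaker inhibition:
compound 1 `O=C(NO)c1ccc(CN2C(=O)NC(Cc3ccccc3)(c3ccccc3)C2=O)cc1` gives 71.9 nM;
compound 2 `CC(C)(C)c1ccc(CC2(c3ccccc3)NC(=O)N(Cc3ccc(C(=O)NO)cc3)C2=O)cc1` gives 115 nM;
compound 3 `O=C(NO)c1ccc(CN2C(=O)NC(CCc3ccccc3)(c3ccccc3)C2=O)cc1` gives 24.7 nM.

Compound 3 holds the lowest number of the three in this assay, set apart from compound 1 by a 2.9-fold lower number from compound 1 to compound 3 (0.46 log units; beyond the scatter) and from compound 2 by a 4.7-fold lower number from compound 2 to compound 3 (0.67 log units; beyond the scatter). Compound 4 `O=C(NO)c1ccc(CN2C(=O)NC(Cc3ccc4ccccc4c3)(c3ccccc3)C2=O)cc1` differs from compound 3 by naphthalen-2-yl in place of benzyl on a saturated chain carbon bound to a saturated ring carbon. Within the data shown here, two measured steps bear on this change. The step of a 2.9-fold lower number from compound 1 to compound 3 (0.46 log units; beyond the scatter) shows that extending the group on that chain carbon from phenyl to benzyl lowers the number, whereas the step of a 1.6-fold higher number from compound 1 to compound 2 (0.20 log units; within the scatter) shows that enlarging the aromatic part with tert-butyl leaves the number essentially where it was. Compound 4 keeps the shorter spacing of compound 1 and compound 2 and enlarges the aromatic part instead, so it resembles the second kind of step more than the first. The step is therefore expected to be a 1.6-fold higher number from compound 3 to compound 4 (0.21 log units; within the scatter), pointing toward a higher number if anywhere, and quite possibly not beyond the scatter. Compound 4 is estimated at 40 nM, with a range from 15 nM to 110 nM.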

Compound 4, half-maximal inhibitory concentration: 74.6 nM
Beside the measured number, compound 4's estimate is 1.9-fold (0.27 log units) below it; the measured number falls inside the stated range.
By their numbers in this assay, from the lowest: compound 3; then compounds 1, 4 and 2 (each within the scatter of the next).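

In this assay, the change from phenethyl to (naphthalen-2-yl)methyl gives up the advantage held by compound 3, with a 3.0-fold higher number from compound 3 to compound 4 (0.48 log units; beyond the scatter), so the second aromatic ring does not take the place of the longer chain at this position. Compound 4 instead sits with the two compounds that share its single carbon spacing, with a 1.0-fold higher number from compound 1 to compound 4 (0.02 log units; within the scatter) and a 1.5-fold lower number from compound 2 to compound 4 (0.19 log units; within the scatter), so among compounds 1, 2 and 4 neither tert-butyl nor the naphthalen-2-yl ring system moves the number beyond the scatter, and compound 3 is the only one of the four that stands apart from the rest at this position. Nothing available explains why the phenethyl group gives the lower number.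

Going by these compounds, it remains open whether a still longer chain, such as 3-phenylpropyl, would lower the number further, and whether 2-(naphthalen-2-yl)ethyl or 4-(tert-butyl)phenethyl would keep the level of compound 3 once the longer spacing and the larger aromatic part are combined. Also open, on these data alone, is how a dimethylamino group or a carboxylic acid on the phenyl ring of the phenethyl group would affect the number.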